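The source may report more compounds than this note shows. Statements on the series, on what has been measured and on what is new or still open speak of the compounds shown alone.

Working notes on the series. The shared core of compound 1 `O=C(Nc1cccc(-n2cc(-c3ccncc3)c(-c3cc(O)cc(Cl)c3)n2)c1)Nc1ccc(Cl)c(C(F)(F)F)c1` carries a urea to an aryl ring bearing chloro and trifluoromethyl; in a functional assay on SW-620 cells (Homo sapiens) for inhibition, read by sulforhodamine B assay, with a stated time of 48 h, tested at 0.1 uM (on this read-out higher numbers stand for a weaker effect at the one concentration tested and lower numbers for a stronger effect), compound 1 gives 98%. Among the measured compounds shown here, compound 2 `O=C(Nc1cccc(-n2cc(-c3ccncc3)c(-c3cc(O)cc(Cl)c3)n2)c1)Nc1ccc(Cl)c(Cl)c1` differs from it in one place, and in this assay compound 2 gives 99%; the step of a number 1 percentage points higher from compound 1 to compound 2 (within the scatter) is the only single-point step measured so far. Compound 3 `COc1cc(Cl)cc(-c2nn(-c3cccc(NC(=O)Nc4cc(C(F)(F)F)cc(C(F)(F)F)c4)c3)cc2-c2ccncc2)c1` carries a methoxy in place of the hydroxy and a different urea aryl ring, and in this assay compound 3 gives 94%. Compound 2 stands nearest to compound 1 and furthest from compound 3, with both gaps inside the scatter, so the three numbers are indistinguishable on this read-out.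

Compound 4 `COc1cc(Cl)cc(-c2nn(-c3cccc(NC(=O)Nc4ccc(Cl)c(Cl)c4)c3)cc2-c2ccncc2)c1` is obtained from compound 2 by the change (methyl in place of hydrogen on an oxygen on an aromatic ring). For the measured compounds named here, no measured step follows this change alone; the step of a number 1 percentage points higher from compound 1 to compound 2 (within the scatter) concerns a different position and was within the scatter, and compound 3, which already carries the methoxy, differs from compound 1 in two places and gives a number within the scatter of both. On the numbers shown, compound 4 is therefore expected to give a step of a number 2 percentage points lower from compound 2 to compound 4 (within the scatter), that is none beyond the scatter. The estimate for compound 4 in this assay is 97%, expected between 88% and 102%.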

Compound 4, a percentage reported as activity, at one concentration (the size of the read-out at that concentration, not a potency): 97%
For compound 4 middle estimate and measured number coincide at the digits printed; the measured number falls inside the stated range.
By their numbers in this assay, from the lowest: compounds 3, 4, 1 and 2 (each within the scatter of the next).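

Among the compounds shown here, the step of a number 2 percentage points lower from compound 2 to compound 4 (within the scatter) is the first single-point reading at this position, and it shows that in this assay, with the rest of compound 2 held constant, hydroxy to methoxy on the 3-chloro-5-hydroxyphenyl ring produces no difference beyond the scatter. The earlier pair of compound 1 and compound 3 could not show this, since those two differ in two places. Together with a number 1 percentage points higher from compound 1 to compound 2 (within the scatter), at the urea aryl ring, both single-point steps now available lie within the scatter, so neither of these two places separates compounds on this read-out at the one concentration tested, and nothing measured here offers an explanation for that.

From the compounds shown here alone, what an ethoxy, an amine or a carboxylic acid would give in place of the hydroxy stays open, as the reading at this place rests on hydrogen and methyl on the oxygen alone. Also open, going by these compounds, is whether compound 2 and compound 4 would separate at other concentrations, since a single-concentration percentage is not a potency.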